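Extending the Nitrate Chain on a Shared Core

The source may hold more compounds than are shown below. What is called first, only, known or untested is meant among the compounds shown, and "the series" means these compounds.

Three measured compounds share one core and each carries a nitrooxy group on a side chain. Compound 1 `O=C1c2ccccc2C(=O)N1CCO[N+](=O)[O-]`, compound 2 `O=C1c2ccccc2C(=O)N1c1cccc(CO[N+](=O)[O-])c1` and compound 3 `O=C1c2ccccc2C(=O)N1c1ccc(CO[N+](=O)[O-])cc1` were tested in a functional assay on the whole organism (Ear, strain Swiss albino) for inhibition, with Mus musculus as the target, with stated times of 1 h and 30 min, at a dose of 300 umol/kg by the oral route; a higher number here means more inhibition at the dose given (going by the name of the read-out), a lower number less inhibition. In this assay compound 1 gives 43%, compound 2 gives 43%, and compound 3 gives 43%. The three values agree at the digits shown, so compound 3 stands level with the other two, and nothing separates any pair of them beyond the usual scatter. Among the compounds with values here, no step between measured compounds that differ in a single place is available, so the data give no direct reading of how a change on the side chain moves the read-out.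

Compound 4 `O=C1c2ccccc2C(=O)N1c1ccc(CCO[N+](=O)[O-])cc1` has not yet been measured. Its difference from compound 3, counted from the two structures, is (nitrooxy)methyl in place of nitrooxy on a saturated chain carbon bound to an aromatic carbon. Cut one bond further out, the same difference reads (nitrooxy)methyl to 2-(nitrooxy)ethyl.

The three measured values stand level, so the step expected here, no change at the digits printed from compound 3 to compound 4 (within the scatter), is none beyond the scatter. Compound 4 is therefore estimated at 43% in this assay, with a range from 30% to 56%.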

Compound 4, a percentage reported as inhibition, in the whole organism at one dose (the size of the read-out at that dose, not a potency): 43%
Estimate against measurement, compound 4: no gap at the digits printed; low and high end bracket the measured number.
By their numbers in this assay, from the lowest: compounds 1, 2, 3 and 4 (each within the scatter of the next).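

In this assay, the change from (nitrooxy)methyl to 2-(nitrooxy)ethyl gives no change at the digits printed from compound 3 to compound 4 (within the scatter). Within the data shown here, this is the first direct comparison here between two compounds that differ in one place only, and it shows that adding one carbon to the chain on a saturated chain carbon bound to an aromatic carbon leaves the inhibition at this single dose without a change beyond the scatter, although such a reading gives the size of the effect at one dose and not a potency. No measurement at hand offers an explanation for this result.

From the compounds shown here alone, whether a longer chain, such as 3-(nitrooxy)propyl, would also stay level remains open, as does the outcome of replacing the nitrooxy group at the chain end with an amine or a carboxylic acid. With only one dose shown, it also remains open whether compound 3 and compound 4 would separate at lower doses, where the inhibition might respond differently to the added carbon.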